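Carbamate to fluoroalkyl ketone on the piperidine nitrogen

The source may hold more compounds than are shown below. What is called first, only, known or untested is meant among the compounds shown, and "the series" means these compounds.

Measured so far:
- compound 1 `Cc1nc(S(C)(=O)=O)ccc1Oc1ncnc(OC2CCN(C(=O)OC(C)(C)C(F)(F)F)CC2)c1F`: 79%
- compound 2 `Cc1nc(S(C)(=O)=O)ccc1Oc1ncnc(OC2CCN(C(=O)O[C@H](C)CF)CC2)c1F`: 79%
- compound 3 `Cc1nc(S(C)(=O)=O)ccc1Oc1ncnc(OC2CCN(C(=O)SC(C)C)CC2)c1F`: 81%

All three share one core and differ only in the group on the carbonyl carbon attached to the ring nitrogen. In a functional assay on isolated protein for inhibition of Glucose-dependent insulinotropic receptor (Rattus norvegicus), read by HTRF and cAMP accumulation (on this read-out lower numbers stand for smaller maximal responses and higher numbers for larger maximal responses), compound 2 sits level with compound 1, the two together at the lowest of the three numbers, and no change at the digits printed from compound 1 to compound 2 (within the scatter). Compound 3 lies above both by the same small amount: a number 2 percentage points higher from compound 1 to compound 3 (within the scatter) and a number 2 percentage points higher from compound 2 to compound 3 (within the scatter). None of these steps leaves the scatter.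

Compound 4 `Cc1nc(S(C)(=O)=O)ccc1Oc1ncnc(OC2CCN(C(=O)C(C)(C)F)CC2)c1F` is not yet measured. Relative to compound 2 the change is a group of 4 heavy atoms (3 carbon, 1 fluorine; no ring) in place of a group of 5 heavy atoms (3 carbon, 1 oxygen, 1 fluorine; no ring), on a carbonyl carbon, with 1-fluoro-1-methylethyl entering on the carbonyl carbon. For the measured compounds named here, the closest precedent is the step from compound 2 to compound 3, also a swap of a larger group for a smaller one at that carbonyl carbon, which stayed within the scatter, as did the step from compound 1 to compound 2. The expected step is therefore a number 1 percentage points higher from compound 2 to compound 4 (within the scatter), that is none beyond the scatter. Compound 4 is estimated at 80%, ranging from 70% to 90%.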

Compound 4, largest response reached (reported as efficacy), in percent of the reference or control that the assay uses: 74%
Compound 4: middle estimate off by 6 percentage points, on the high side, and the stated range covers the measured number.
By their numbers in this assay, from the lowest: compounds 4, 1, 2 and 3 (each within the scatter of the next).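

For the compounds shown here, compound 4 is the first compound here with a carbon-linked group, 1-fluoro-1-methylethyl, on the carbonyl carbon, and in this assay all three steps to it stay within the scatter (a number 5 percentage points lower from compound 2 to compound 4 (within the scatter)) (a number 5 percentage points lower from compound 1 to compound 4 (within the scatter)) (a number 7 percentage points lower from compound 3 to compound 4 (within the scatter)). On this carbonyl carbon, whose other neighbour is the amide-type nitrogen in a ring, the maximal response is therefore kept when the carbamate and thiocarbamate links give way to a ketone, with an entering group that has no hydrogen-bond acceptor and no defined stereocentre. Nothing available explains these numbers.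

On these data alone, whether a plain isopropyl group without fluorine would keep the same response remains open. So does the outcome with an amine on the carbonyl carbon, which would give a urea, or with a longer chain.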